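The compounds below may be only part of what the source reports. "The series", "measured", "known", "first", "only" and "open" are said of these compounds alone.

Measured values in an ADME assay on HEK293 cells (Homo sapiens) for cytotoxicity, read by luminescence, with a stated time of 72 h; on this read-out lower numbers stand for an effect already at smaller amounts and higher numbers for an effect only at larger amounts of compound
- compound 1 (`CCOC(=O)c1c(-c2cccc(Oc3ccccc3)c2)[nH]c2cc(OC)c(F)cc2c1=O`) gives > 22000 nM
- compound 2 (`CCOC(=O)c1c(-c2cccc(-c3ccccc3Cl)c2)[nH]c2cc(OC)c(F)cc2c1=O`) gives > 22000 nM
- compound 3 (`CCOC(=O)c1c(-c2cccc(Oc3c(C)cccc3C)c2)[nH]c2cc(OC)c(F)cc2c1=O`) gives > 22000 nM

All three entries are limits and not numbers. Compound 1 stands at the limit of > 22000 nM in this assay, at which 3 of the 3 values shown sit.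

Compound 4 (`COc1cc2[nH]c(-c3cccc(Oc4ccccc4)c3)c(C(=O)OCCO)c(=O)c2cc1F`) differs from compound 1 by hydroxy in place of hydrogen on a saturated chain carbon, two bonds along the chain from an oxygen next to a carbonyl group (ethyl to 2-hydroxyethyl). The measured steps, a step that the two limits leave unreadable from compound 1 to compound 2 and a step that the two limits leave unreadable from compound 1 to compound 3, change a different group and give no size to carry over.

In this assay the expected outcome for compound 4 is a number no higher from compound 1 to compound 4 (the limit leaves the size open), with no shift beyond the scatter. Compound 4 is estimated at 22000 nM, with an expected range of 10000 nM to 40000 nM. Another limit reading is likely.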

Compound 4, half-maximal effective concentration: > 22000 nM
Compound 4 ended at the assay's limit; the forecaster's own chance of this, stated with the estimate: 80%; the middle value lies on the limit itself.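

No step can be read between compound 1 and compound 4: both entries are limits, not numbers. The compounds shown leave open whether in this assay ethyl to 2-hydroxyethyl shifts the effect, and at what concentration any of the four acts.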